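Oxan-4-yl in place of phenyl on an aromatic carbon

The compounds below may be only part of what the source reports. "The series", "measured", "known", "first", "only" and "open" are said of these compounds alone.

In an ADME assay on the whole organism (Mus musculus) for metabolic stability, read by LC-MS, with a stated time of 24 h (on this read-out higher numbers stand for a longer-lived compound and lower numbers for a shorter-lived compound), compound 1 `COc1ccc(-c2cnn(C)c2)c2nc(NC(=O)N3CCC(C)(O)CC3)[nH]c12` gives 0.867 h and compound 2 `COc1ccc(-c2cnn(C)c2)c2nc(NC(=O)N3CC[C@@]4(CCCOC4)C3)[nH]c12` gives 1.11 h. Within the data shown here, the one measured step, a 1.3-fold higher number from compound 1 to compound 2 (0.11 log units; within the scatter), changes the group on the carbonyl carbon and stays within the scatter. The core of compound 1 differs from that of compound 3 `COc1ccc(-c2ccccc2)c2ncc(NC(=O)N3CCC(C)(O)CC3)nc12`. Compound 3 is known only as a limit, > 2 h.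

Compound 4 `COc1ccc(C2CCOCC2)c2ncc(NC(=O)N3CCC(C)(O)CC3)nc12` keeps the core of compound 3 and its group on the carbonyl carbon. It carries oxan-4-yl in place of phenyl on an aromatic carbon, para to a methoxy group (oxan-4-yl in place of phenyl on an aromatic carbon). Among the measured compounds shown here, no measured step touches this place, so the step of a 1.3-fold higher number from compound 1 to compound 2 (0.11 log units; within the scatter) gives only a weak guide, and no change beyond the scatter is expected in this assay, in either direction. The expected change is an at least 1.1-fold lower number from compound 3 to compound 4 (0.04 log units; that floor lies within the scatter), and it is uncertain since it starts from a limit. For compound 4 the estimate is 1.8 h, with an expected range from 0.8 h to 4 h.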

Compound 4, half-life: 0.92 h
Compound 4: the middle estimate sits 2.0-fold (0.29 log units) above what was measured; low and high end bracket the measured number.
By their numbers in this assay, from the lowest: compounds 1, 4 and 2 (each within the scatter of the next). At a limit, above all of these: compound 3.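

In this assay, among these compounds, this is the first measured change at this place, on an aromatic carbon para to a methoxy group, and oxan-4-yl in place of phenyl gives an at least 2.1-fold lower number from compound 3 to compound 4 (0.33 log units; beyond the scatter). The earlier step on the carbonyl carbon, a 1.3-fold higher number from compound 1 to compound 2 (0.11 log units; within the scatter), showed no change beyond the scatter, so this position is the first shown to move the read-out beyond it. Compound 3 is known only as a limit, and the step from it is a floor whose full size stays unknown: the limit of > 2 h in this assay, at which 1 of the 4 values shown sits.

The change swaps an aromatic ring of carbon only for a non-aromatic ring with a hetero atom, and this single pair cannot separate the loss of aromaticity from the entry of the ring oxygen. Cyclohexyl or a piperidin-4-yl amine at this place would bear on that, and whether the step carries over to the core of compound 1 remains open.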